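Adding a Second Chloro to Compound 1

The source may hold more compounds than are shown below. What is called first, only, known or untested is meant among the compounds shown, and "the series" means these compounds.

Compound 1 `O=C(CNC(=O)c1cc(Cl)ccc1O)Nc1cccc(Cl)c1` was tested in a functional assay on K562 cells (Homo sapiens) for cytotoxicity, with a stated time of 72 h (a lower number here means a stronger inhibitor, a higher number a weaker inhibitor), where compound 1 gives only a limit, > 10000 nM. Compound 2 `CC(C)[C@H](NC(=O)c1cc(Cl)ccc1O)C(=O)Nc1cccc(Cl)c1` likewise gives only a limit in this assay, > 10000 nM. The step that the two limits leave unreadable from compound 1 to compound 2 is unreadable, since both values sit at the same edge, (the limit of > 10000 nM in this assay, at which 2 of the 2 values shown sit). Compound 3 `O=C(CNC(=O)c1cc(Cl)ccc1O)Nc1ccc(Cl)c(Cl)c1` differs from compound 1 by chloro in place of hydrogen on an aromatic carbon. Within the data shown here, no measured step bears on this change, and neither measured compound supplies a number to move from. Compound 3 is therefore expected to give about 15000 nM, between 3000 nM and 60000 nM. The expected step is a step that the limit leaves unreadable from compound 1 to compound 3, most likely hidden beyond the limit.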

Compound 3, half-maximal inhibitory concentration: > 20000 nM
Compound 3 was reported as a limit; the forecaster's own chance of this, stated with the estimate: 80%; at least 1.3-fold (0.12 log units) between middle value and limit.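

In this assay compound 3 gives > 20000 nM as a limit only. Among these compounds, compound 1 likewise gives only a limit, so no step between compound 1 and compound 3 can be read. Going by these compounds, whether chloro in place of hydrogen on an aromatic carbon changes cytotoxicity at all remains open.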